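This account rests on a few compounds, and the source may have more. Where it says the series, first, only, none or still open, it means among the compounds named here.

In an ADME assay on microsomes from liver (Homo sapiens) for metabolic stability (a higher number here means faster removal of the compound, a lower number slower removal), compound 2 `CCCC(Oc1ccc(-n2cc3ccccc3n2)cc1)c1ccc(C(=O)NCCC(=O)O)cc1` gives 44 mL/min/kg. Compound 3 `O=C(O)CCNC(=O)c1ccc(C(Oc2ccc(-n3cc(C(F)(F)F)cn3)cc2)C2CCC2)cc1` gives 26 mL/min/kg, and these two values lie within the scatter of each other. Compound 1 `O=C(O)CCNC(=O)c1ccc(C(Oc2ccc(-n3cc(C(F)(F)F)cn3)cc2)C2CC2)cc1` is reported only as a limit, < 8 mL/min/kg.

Compound 4 `CCCC(Oc1ccc(-n2cc(C(F)(F)F)c(C)n2)cc1)c1ccc(C(=O)NCCC(=O)O)cc1` differs from compound 2 in one place, on an aromatic carbon para to a large group: 3-methyl-4-(trifluoromethyl)-1H-pyrazol-1-yl in place of 2H-indazol-2-yl on an aromatic carbon. Here 3-methyl-4-(trifluoromethyl)-1H-pyrazol-1-yl stands in place of 2H-indazol-2-yl, while the propyl chain of compound 2 stays. Among the measured compounds shown here, no measured step makes this exchange. For the measured compounds named here, the only measured step, an at least 3.2-fold higher number from compound 1 to compound 3 (0.51 log units; beyond the scatter), is cyclobutyl in place of cyclopropyl on a saturated chain carbon, so it bears on the change only indirectly. Compounds 1 and 3 both carry a trifluoromethyl group on a five-membered aromatic ring with 2 hetero atoms, yet that step separates them, so the presence of this group does not settle the number.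

With compound 3 at 26 mL/min/kg as the nearest guide, no change beyond the scatter is expected in this assay. The expected step, a 1.5-fold lower number from compound 2 to compound 4 (0.17 log units; within the scatter), is a small one toward a lower number. For compound 4 the estimate is 30 mL/min/kg, with an expected range from 14 mL/min/kg to 60 mL/min/kg.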

Compound 4, clearance: < 10 mL/min/kg
Compound 4: only a limit was reported (the forecaster's own chance of this, stated with the estimate: 7%); at least 3.0-fold (0.47 log units) between middle value and limit.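

In this assay, the exchange of 2H-indazol-2-yl for 3-methyl-4-(trifluoromethyl)-1H-pyrazol-1-yl on an aromatic carbon para to a large group, with the propyl chain unchanged, brings an at least 4.4-fold lower number from compound 2 to compound 4 (0.64 log units; beyond the scatter), so a change at this position alone can move the number beyond the scatter. Among the compounds shown here, the only step available before this one, an at least 3.2-fold higher number from compound 1 to compound 3 (0.51 log units; beyond the scatter), lay at a saturated chain carbon and said nothing directly about this aromatic position; there are now single-change steps beyond the scatter at both places. Going by these compounds, the reading for compound 4 is a limit and not a number, so the true size of the new step remains unknown: the limit of < 10 mL/min/kg in this assay, at which 1 of the 4 values shown sits.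

The exchange replaces the whole of 2H-indazol-2-yl at once, and the compounds shown do not separate the part played by the trifluoromethyl group from that of the methyl group or from the loss of the six-membered aromatic ring. On these data alone, it also remains open how this assay would read with a nitrile in place of the trifluoromethyl group, or with a longer chain in place of propyl while 3-methyl-4-(trifluoromethyl)-1H-pyrazol-1-yl stays.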